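Methyl to ethyl on compound 1

This account rests on a few compounds, and the source may have more. Where it says the series, first, only, none or still open, it means among the compounds named here.

Measured in a functional assay on M21 cells (Homo sapiens) for antiproliferative activity, read by sulforhodamine B assay, with a stated time of 48 h; a higher number here means a weaker inhibitor, a lower number a stronger inhibitor
- compound 1 `CN1CCN(c2ccc(S(=O)(=O)Oc3cccc(Br)c3)cc2)C1=O` gives 1300 nM
- compound 2 `CN1CCN(c2ccc(S(=O)(=O)Oc3cccc(I)c3)cc2)C1=O` gives 400 nM
- compound 3 `CN1CCN(c2ccc(S(=O)(=O)Oc3ccc(Cl)cc3)cc2)C1=O` gives 43000 nM

Compound 1 holds the second highest of the three numbers, with compound 2 lower and compound 3 higher. Compound 4 `CCN1CCN(c2ccc(S(=O)(=O)Oc3cccc(Br)c3)cc2)C1=O` is still unmeasured and differs from compound 1 thus: methyl in place of hydrogen on a saturated chain carbon bound to an amide-type nitrogen in a ring. The measured steps are a 3.3-fold lower number from compound 1 to compound 2 (0.51 log units; beyond the scatter), a 33-fold higher number from compound 1 to compound 3 (1.52 log units; beyond the scatter) and a 110-fold higher number from compound 2 to compound 3 (2.03 log units; beyond the scatter). All three concern the halogenated phenyl group on the oxygen, so none tests this place directly, and their sizes transfer poorly. No step beyond the scatter is therefore expected, in either direction. The expected change is a 1.3-fold lower number from compound 1 to compound 4 (0.11 log units; within the scatter). Compound 4 is estimated at 1000 nM, with an expected range of 350 nM to 3000 nM.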

Compound 4, half-maximal inhibitory concentration: 3400 nM
The estimate for compound 4 lay 3.4-fold (0.53 log units) below the measured number, and the stated range ends below it.
By their numbers in this assay, from the lowest: compound 2; then compound 1; then compound 4; then compound 3.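

The substituent on the ring amide-type nitrogen is not a silent place in the series: in this assay, methyl to ethyl gives a 2.6-fold higher number from compound 1 to compound 4 (0.42 log units; beyond the scatter), a step beyond the scatter. For the compounds shown here, this is the first read on this position, and the added methyl, a single heavy atom, moves the number upward. No measurement bears on the reason for this step.

Open, as far as these compounds go, is whether a propyl chain or a hydroxyethyl group would continue this direction, and whether hydrogen in place of the methyl of compound 1 would reverse it. Also open, from the compounds shown here alone, is whether the ethyl change carries over to the 3-iodophenyl compound 2.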